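The compounds below may be only part of what the source reports. "The series", "measured", "known", "first", "only" and "open" are said of these compounds alone.

Compound 1, `Cc1ccc(C2=NN(c3nc(-c4ccc(Cl)cc4)cs3)C(c3ccc(F)cc3)C2)s1`, in an ADME assay on NIH3T3 cells (Mus musculus) for cytotoxicity, read by XTT assay, with a stated time of 24 h (a higher number here means a weaker inhibitor, a lower number a stronger inhibitor), gives > 500 ug/mL, which is a limit of the assay.
Compound 2, `Cc1ccc(C2=NN(c3nc(-c4ccc(F)cc4)cs3)C(c3ccc(F)cc3)C2)s1`, gives > 500 ug/mL, also a limit.
Compound 3, `Cc1ccc(C2=NN(c3nc(-c4ccc(S(C)(=O)=O)cc4)cs3)C(c3ccc(F)cc3)C2)s1`, gives 374 ug/mL.

Compound 3 is the only one of the three with an actual number in this assay; the other two values sit at the limit of > 500 ug/mL in this assay, at which 2 of the 3 values shown sit. Compound 4, `Cc1ccc(C2=NN(c3nc(-c4ccccc4)cs3)C(c3ccc(F)cc3)C2)s1`, is the next step from compound 3: hydrogen in place of methylsulfonyl on an aromatic carbon.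

Among the measured compounds shown here, two measured steps bear on this change, both read toward compound 3. Introducing methylsulfonyl gave an at least 1.3-fold lower number from compound 1 to compound 3 (0.12 log units; that floor lies within the scatter) and an at least 1.3-fold lower number from compound 2 to compound 3 (0.12 log units; that floor lies within the scatter), each a floor that lies within the scatter, so neither shows a clear effect. The step that the two limits leave unreadable from compound 1 to compound 2 gives no readable size. Taking the methylsulfonyl away again, going from compound 3 to compound 4, is therefore expected to move the number back upward by a small amount, toward the limit where compound 1 and compound 2 sit, with a 1.3-fold higher number from compound 3 to compound 4 (0.13 log units; within the scatter) as the expected size.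

For compound 4 the estimate in this assay is 500 ug/mL, with a likely range from 300 ug/mL to 900 ug/mL, and a fair chance that only a limit is reported.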

Compound 4, half-maximal inhibitory concentration: > 500 ug/mL
Compound 4 ended at the assay's limit; the forecaster's own chance of this, stated with the estimate: 55%; the middle value sits exactly at the limit.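

In this assay, the plain phenyl of compound 4 behaves like the chloro compound 1 and the fluoro compound 2, so hydrogen now joins the two halogens on this aromatic carbon, para to a large group, in ending at the limit, and compound 3, with its methylsulfonyl, stands alone in giving an actual number: the limit of > 500 ug/mL in this assay, at which 3 of the 4 values shown sit. Hydrogen in place of methylsulfonyl gives an at least 1.3-fold higher number from compound 3 to compound 4 (0.12 log units; that floor lies within the scatter), so the direct removal of the group, the cleanest comparison at this position so far, still shows no clear effect. The steps that link compound 4 to compound 1 and to compound 2 run between two limits and cannot be read.

The compounds shown leave open how large any effect of the methylsulfonyl group is, as the true values of the other three compounds remain hidden behind their limits. They also leave open whether an amine, a carboxylic acid or a longer chain at this position would bring the number clearly down from the limit.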